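Hydroxyphenyl swap in a two-compound series

This account rests on a few compounds, and the source may have more. Where it says the series, first, only, none or still open, it means among the compounds named here.

Of the compounds shown here, two carry numbers so far. Compound 1 `Oc1ccc(-c2cc(-c3ccco3)cc(-c3cccc(O)c3)n2)cc1` in an assay on isolated protein for inhibition of DNA topoisomerase 1 (Homo sapiens), with a stated time of 30 min, tested at 20 uM (on this read-out higher numbers stand for a stronger effect at the one concentration tested and lower numbers for a weaker effect), gives 1.5%. Compound 2 `Oc1cccc(-c2cc(-c3ccoc3)cc(-c3cccc(O)c3)n2)c1` in this assay gives 2%; on the two numbers shown it stands at the upper end, but compound 1 lies within the scatter of it, so the two are not separable on this read-out. Both figures are low.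

Compound 3 `Oc1ccc(-c2cc(-c3ccoc3)cc(-c3cccc(O)c3)n2)cc1` is not yet measured. It differs from compound 2 by 4-hydroxyphenyl in place of 3-hydroxyphenyl on an aromatic carbon. Among the measured compounds shown here, no measured pair shows this change on its own. Compound 1, which already carries a 4-hydroxyphenyl group, gives 1.5%, so the series gives no sign that a 4-hydroxyphenyl group raises the read-out. For compound 3 the step of no change at the digits printed from compound 2 to compound 3 (within the scatter) is expected to be none beyond the scatter. Compound 3 in this assay is estimated at 2%, between -6% and 10%.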

Compound 3, a percentage reported as inhibition, at one concentration (the size of the read-out at that concentration, not a potency): 1.3%
The estimate for compound 3 lay 0.7 percentage points above the measured number, within the range that was stated.
By their numbers in this assay, from the lowest: compounds 3, 1 and 2 (each within the scatter of the next).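

With this pair, the swap of 3-hydroxyphenyl for 4-hydroxyphenyl on the aromatic carbon next to the ring nitrogen can be read on its own in this assay: the change gives a number 0.7 percentage points lower from compound 2 to compound 3 (within the scatter), so moving the hydroxyl within this group does not separate the two compounds on this read-out. The second pair adds a change elsewhere on the core, furan-3-yl in place of furan-2-yl, and gives a number 0.2 percentage points lower from compound 1 to compound 3 (within the scatter), so that change does not separate its two compounds either. No supporting data accompany these steps that could account for either result.

All three numbers are low, so the pairs cannot show whether either position can move the read-out at all. On these data alone, whether an aminophenyl or carboxyphenyl group at the first position, or an amine on a longer chain in place of the furan, would do so remains open.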